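The source may hold more compounds than are shown below. What is called first, only, known or untested is meant among the compounds shown, and "the series" means these compounds.

Compound 2 `CN1CCN(c2ccc(Nc3ncc4nc(Nc5ccc(F)cc5)n([C@@H]5CCN(C(=O)OC(C)(C)C)C5)c4n3)cc2)CC1` sits at the high end of the three numbers recorded in a functional assay on HCC827 cells (Homo sapiens) for antiproliferative activity, read by MTT assay, with a stated time of 72 h (on this read-out higher numbers stand for weaker inhibition and lower numbers for stronger inhibition), where compound 2 gives 27 nM. Its nearest neighbour is compound 1 `CN1CCN(c2ccc(Nc3ncc4nc(Nc5ccccc5)n([C@@H]5CCN(C(=O)OC(C)(C)C)C5)c4n3)cc2)CC1`, which in this assay gives 12 nM; the step of a 2.3-fold higher number from compound 1 to compound 2 (0.35 log units; beyond the scatter) marks this as a modest weakening. Further off is compound 3 `CN1CCN(c2ccc(Nc3ncc4nc(Nc5ccccc5)n([C@@H]5CCN(S(=O)(=O)C6CC6)C5)c4n3)cc2)CC1`, which in this assay gives 0.88 nM, and the step of a 14-fold lower number from compound 1 to compound 3 (1.13 log units; beyond the scatter) shows a large strengthening.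

Compound 4 `CN1CCN(c2ccc(Nc3ncc4nc(Nc5ccc(F)cc5)n([C@@H]5CCN(C(=O)CO)C5)c4n3)cc2)CC1` differs from compound 2 in one place: hydroxymethyl in place of tert-butoxy on a carbonyl carbon. Among the compounds with values here, no measured pair exchanges tert-butoxy for hydroxymethyl, so the only step that bears on this change is a 14-fold lower number from compound 1 to compound 3 (1.13 log units; beyond the scatter), which replaced the whole tert-butoxycarbonyl on the same ring nitrogen and gave a large gain. Since compound 4 keeps the carbonyl and swaps only the group on it, a smaller gain is expected, with wide uncertainty: the expected step is a 3.0-fold lower number from compound 2 to compound 4 (0.48 log units; beyond the scatter). Compound 4 is therefore estimated at 9 nM in this assay, within a range from 2.5 nM to 32 nM.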

Compound 4, half-maximal inhibitory concentration: 350 nM
Compound 4: the middle estimate sits 39-fold (1.59 log units) below what was measured; the measured number lies above the stated range.
By their numbers in this assay, from the lowest: compound 3; then compound 1; then compound 2; then compound 4.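

In this assay, within the data shown here, putting hydroxymethyl in place of tert-butoxy on a carbonyl carbon gives a 13-fold higher number from compound 2 to compound 4 (1.11 log units; beyond the scatter), so changes on this ring nitrogen can cost activity as well as gain it, whereas the only earlier step here, a 14-fold lower number from compound 1 to compound 3 (1.13 log units; beyond the scatter), was a gain. The carbonyl stays in place in this change, so the group attached to it is enough on its own to produce a large step. Nothing available explains why this exchange weakens the result.

From the compounds shown here alone, it stays open whether the loss follows the hydroxyl or simply the smaller group, a question that a methyl or methoxy on the same carbonyl could help settle. An amine or a longer chain in that place could show how far the trend extends.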